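An Amide Swap in a Series Without Readable Potency

A few compounds are considered here, and "the series" means these few. Any claim that something is new, unique, unknown or untested is made for them only; others in the source may bear on it.

Compound 3 `COc1ccc(OC)c(-c2cc(-c3ccc(C(=O)N(C)Cc4ccc(F)cc4)s3)on2)c1` is one of a small set of amides built on a shared core. In a functional assay on A549 cells (Homo sapiens) for cytotoxicity, read by XTT assay, with a stated time of 72 h (a higher number here means a weaker inhibitor, a lower number a stronger inhibitor), compound 3 gives > 30000 nM, which is a limit of the assay rather than a number. Compound 1 `COc1ccc(OC)c(-c2cc(-c3ccc(C(=O)N(C)C)s3)on2)c1` gives > 30000 nM in this assay, also a limit. Compound 2 `COc1ccc(OC)c(-c2cc(-c3ccc(C(=O)N(C)Cc4ccccc4)s3)on2)c1` gives > 30000 nM in this assay, again a limit. The steps a step that the two limits leave unreadable from compound 1 to compound 2, a step that the two limits leave unreadable from compound 1 to compound 3 and a step that the two limits leave unreadable from compound 2 to compound 3 therefore cannot be sized, since (the limit of > 30000 nM in this assay, at which 3 of the 3 values shown sit).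

Compound 4 `COc1ccc(OC)c(-c2cc(-c3ccc(C(=O)N4CCC(C(F)(F)F)CC4)s3)on2)c1` differs from compound 3 in one place: 4-(trifluoromethyl)piperidin-1-yl in place of (4-fluorobenzyl)(methyl)amino on a carbonyl carbon. Among the compounds with values here, none of the measured steps concerns this kind of replacement, and none of them is readable at all; every change made so far at the amide nitrogen has left the value at the limit. With nothing to suggest a move into the measurable range, compound 4 is expected to give 45000 nM, within 12000 nM to 150000 nM, and most likely to be reported once more only as a limit. The step that the limit leaves unreadable from compound 3 to compound 4 is accordingly expected to be no more than the scatter.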

Compound 4, half-maximal inhibitory concentration: > 30000 nM
Compound 4: only a limit was reported (the forecaster's own chance of this, stated with the estimate: 80%); the middle value lies beyond the limit too.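

The steps from compound 1, compound 2 and compound 3 to compound 4 cannot be read, as every value is a limit: the limit of > 30000 nM in this assay, at which 4 of the 4 values shown sit.

The compounds shown leave open whether any amide on the shared core reaches a measurable value in this assay, and how far these four compounds differ.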